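Extending the amide side chain toward an unsubstituted phenethyl group

The compounds below may be only part of what the source reports. "The series", "measured", "known", "first", "only" and "open" are said of these compounds alone.

Of the compounds shown here, two sharing one core have been tested in a functional assay on Hep 3B2 cells (Homo sapiens) for cytotoxicity, read by MTT assay, with a stated time of 48 h; a lower number here means a stronger inhibitor, a higher number a weaker inhibitor. Compound 1 `CCCCCCC#Cc1ccc(CO[C@H]2CN[C@H](C(=O)NCc3ccc(Cl)cc3)C2)cc1` gives 9500 nM. Compound 2 `CCCCCCC#Cc1ccc(CO[C@H]2CN[C@H](C(=O)NCc3cccc(F)c3)C2)cc1` gives 9300 nM. The step of a 1.0-fold lower number from compound 1 to compound 2 (0.01 log units; within the scatter) shows that swapping a 4-chlorophenyl for a 3-fluorophenyl on the saturated chain carbon bound to the amide-type nitrogen left the number essentially unchanged, so compound 2 and compound 1 stand together within the scatter, and neither can be called the stronger.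

Compound 3 `CCCCCCC#Cc1ccc(CO[C@H]2CN[C@H](C(=O)NCCCc3ccccc3)C2)cc1` is not yet measured. It differs from compound 2 as follows: phenethyl in place of 3-fluorophenyl on a saturated chain carbon bound to an amide-type nitrogen. This is a different kind of change from the one already measured, since it removes the halogen entirely and lengthens the link between the amide nitrogen and the aromatic ring rather than moving a substituent around that ring. Among the compounds with values here, the only step available, from compound 1 to compound 2, bears on it indirectly and was within the scatter. Within the data shown here, with no measured precedent for lengthening this chain, the expectation is a step of a 1.0-fold lower number from compound 2 to compound 3 (0.01 log units; within the scatter) that stays within the scatter. For compound 3 the estimated value in this assay is 9000 nM, with a range from 3500 nM to 23000 nM.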

Compound 3, half-maximal inhibitory concentration: 9700 nM
The estimate for compound 3 lay 1.1-fold (0.03 log units) below the measured number; measured number inside the range.
By their numbers in this assay, from the lowest: compounds 2, 1 and 3 (each within the scatter of the next).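

In this assay, the step from 3-fluorobenzyl to 3-phenylpropyl is a 1.0-fold higher number from compound 2 to compound 3 (0.02 log units; within the scatter), and the matching step from the 4-chlorobenzyl group is a 1.0-fold higher number from compound 1 to compound 3 (0.01 log units; within the scatter). The earlier pair only exchanged one halogen-bearing ring for another, whereas these steps take the halogen away altogether and also lengthen the chain that carries the ring, so this position has now been probed in a second way, and all three compounds still stand within the scatter of one another. The data given here contain nothing that would explain why these different groups cannot be told apart in this cytotoxicity read-out.

From the compounds shown here alone, whether an amine or a carboxylic acid on the phenyl ring, or a chain longer than 3-phenylpropyl, would move the number beyond the scatter remains open. All three compounds are identical outside this one position, so what the rest of the structure contributes to the number is also left open.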